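The compounds below may be only part of what the source reports. "The series", "measured", "known", "first", "only" and "open" are said of these compounds alone.

Working notes on the choline kinase alpha series.

Of the compounds shown here, three have been measured in an assay on isolated protein for binding affinity to choline kinase alpha (Homo sapiens), read by surface plasmon resonance; on this read-out lower numbers stand for tighter binding and higher numbers for weaker binding. Compound 1 `COc1ccc(-c2ccc(CN3CCCN(C)CC3)cc2)cc1` gives 3800 nM in this assay. Compound 2 `CN1CCCN(Cc2ccc(-c3cc(F)c(CN4CCCN(C)CC4)c(F)c3)cc2)CC1` gives 259 nM. Compound 3 `CN1CCNCC(Cc2ccc3ncccc3c2)C1` gives 7000 nM. On these numbers compound 1 holds the second highest value of the three; its nearest neighbour is compound 3, whose number lies within the usual scatter of compound 1, so nothing can be said about the order of those two. Compound 2 lies far lower than compound 1, well beyond the scatter.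

Compound 4 `CN1CCCN(Cc2ccc(-c3ccc(CN4CCCN(C)CC4)cc3)cc2)CC1` has not been measured in this assay. It differs from compound 1 in one place: (4-methyl-1,4-diazepan-1-yl)methyl in place of methoxy on an aromatic carbon. Among the measured compounds shown here, no measured pair shows this change alone, so the step has to be inferred. For the measured compounds named here, compound 2 carries the same methyl-diazepanylmethyl group on both outer rings and gives 259 nM, which is the only guide available. The step from compound 1 to compound 4 is expected to be a sizeable drop in dissociation constant, an 8.4-fold lower number from compound 1 to compound 4 (0.93 log units; beyond the scatter), because compound 2 gives 259 nM. Compound 4 is therefore estimated at 450 nM, with a range from 150 nM to 1400 nM; the two fluorine atoms present in compound 2 and absent in compound 4 leave room for a somewhat higher number.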

Compound 4, dissociation constant: 382 nM
Beside the measured number, compound 4's estimate is 1.2-fold (0.07 log units) above it, within the range that was stated.
By their numbers in this assay, from the lowest: compounds 2 and 4 (each within the scatter of the next); then compounds 1 and 3 (each within the scatter of the next).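

In this assay, among the compounds shown here, the exchange of methoxy for (4-methyl-1,4-diazepan-1-yl)methyl on an aromatic carbon, para to a large group, gives a 9.9-fold lower number from compound 1 to compound 4 (1.00 log units; beyond the scatter) and is the first reading of this change on its own. The position therefore accepts a far larger group carrying a seven-membered non-aromatic ring, and binding tightens rather than being lost. For the compounds shown here, until now this group on both outer rings had been seen only with two fluorine atoms on the core, whereas here the step is read without any fluorine. The data on hand offer nothing that accounts for the step, so its origin stays unassigned.

The step changes several things at once, as the incoming group adds a ring, a methylene link and two nitrogen atoms, and these compounds do not separate their contributions. As far as these compounds go, whether a simpler amine such as dimethylaminomethyl, a six-membered 4-methylpiperazin-1-ylmethyl group or a neutral morpholin-4-ylmethyl group would give a step of similar size at this position remains open.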